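Replacing neopentyl with 1-methoxy-1-methylethyl

The source may report more compounds than this note shows. Statements on the series, on what has been measured and on what is new or still open speak of the compounds shown alone.

In an ADME assay on liver for metabolic stability, with Liver microsome (Homo sapiens) as the target, read by LC-MS, using microsomes (a higher number here means faster removal of the compound, a lower number slower removal), compound 1 `O=C(NCc1cc(Cl)ccc1-n1cnnn1)[C@@H]1C[C@@H]2C[C@@H]2N1C(=O)[C@H](O)c1cccc(Cl)c1` sits at > 500 mL.min-1.g-1, a limit of the assay and not a number. Among the compounds with values here, compound 2 `O=C(NCc1cc(Cl)ccc1-n1cnnn1)[C@@H]1C[C@@H]2C[C@@H]2N1C(=O)[C@H](O)C1CCCCC1` gives 150 mL.min-1.g-1, and compound 3 `CC(C)(C)C[C@@H](O)C(=O)N1[C@H](C(=O)NCc2cc(Cl)ccc2-n2cnnn2)C[C@@H]2C[C@@H]21` gives 40 mL.min-1.g-1, the lowest number so far. Neopentyl in place of 3-chlorophenyl brought an at least 12-fold lower number from compound 1 to compound 3 (1.09 log units; beyond the scatter), a large step, and neopentyl in place of cyclohexyl brought a 3.8-fold lower number from compound 2 to compound 3 (0.57 log units; beyond the scatter), a modest one. Compound 4 `COC(C)(C)[C@@H](O)C(=O)N1[C@H](C(=O)NCc2cc(Cl)ccc2-n2cnnn2)C[C@@H]2C[C@@H]21` carries 1-methoxy-1-methylethyl in place of neopentyl on a saturated chain carbon bound to a carbonyl carbon and an oxygen on a saturated carbon. Both measured steps removed a ring, whereas this one exchanges one open chain for another, and they bear on it only loosely. The expectation therefore stays anchored on compound 3 at 40 mL.min-1.g-1. No step beyond the scatter is expected, the estimated change being a 1.3-fold lower number from compound 3 to compound 4 (0.12 log units; within the scatter). For compound 4 the expected value is 30 mL.min-1.g-1, with an estimated range of 12 mL.min-1.g-1 to 75 mL.min-1.g-1.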

Compound 4, intrinsic clearance in microsomes: 40 mL.min-1.g-1
For compound 4 the middle estimate is 1.3-fold (0.12 log units) below the measured one; the range from low to high includes it.
By their numbers in this assay, from the lowest: compounds 3 and 4 (each within the scatter of the next); then compound 2. At a limit, above all of these: compound 1.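

In this assay, 1-methoxy-1-methylethyl in place of neopentyl on this saturated chain carbon brought no change at the digits printed from compound 3 to compound 4 (within the scatter), so this open chain took in an oxygen, and with it a hydrogen-bond acceptor, while the number stayed where neopentyl had left it. Compound 4 also keeps the distance from the ring-bearing compounds, with a 3.8-fold lower number from compound 2 to compound 4 (0.57 log units; beyond the scatter) and an at least 12-fold lower number from compound 1 to compound 4 (1.09 log units; beyond the scatter). Compound 1 stands at a limit of the assay, not at a number, so the last step is only a bound: the limit of > 500 mL.min-1.g-1 in this assay, at which 1 of the 4 values shown sits.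

Only one exchange between open chains is shown here. On these data alone, whether an amine, a carboxylic acid or a longer chain at this carbon would stay at the same number remains open.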